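Swapping chloro for hydroxy on compound 3

The compounds below may be only part of what the source reports. "The series", "measured", "known", "first", "only" and "open" are said of these compounds alone.

Of the compounds shown here, three sharing one core have been measured in a functional assay on HepG2 cells (Homo sapiens) for inhibition, read by MTT assay, with a stated time of 24 h (on this read-out lower numbers stand for stronger inhibition and higher numbers for weaker inhibition), and they differ only in the halogen on a six-membered aromatic ring of carbon only. Compound 1 `CC1(C)[C@H]2CC[C@]1(C)N(Cc1cn(-c3ccccc3Br)nn1)C(=O)C2`, which carries bromo, gives 150 nM. Compound 2 `CC1(C)[C@H]2CC[C@]1(C)N(Cc1cn(-c3ccccc3F)nn1)C(=O)C2`, which carries fluoro, gives 60 nM. Compound 3 `CC1(C)[C@H]2CC[C@]1(C)N(Cc1cn(-c3ccccc3Cl)nn1)C(=O)C2`, which carries chloro, gives 60 nM, so it shares the lowest number of the three with compound 2.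

Compound 4 `CC1(C)[C@H]2CC[C@]1(C)N(Cc1cn(-c3ccccc3O)nn1)C(=O)C2` has not yet been measured. It is hydroxy in place of chloro on an aromatic carbon, ortho to a large group: hydroxy in place of chloro on an aromatic carbon.

Three measured steps offer a guide to size. Going from bromo to fluoro gives a 2.5-fold lower number from compound 1 to compound 2 (0.40 log units; beyond the scatter), and going from bromo to chloro gives a 2.5-fold lower number from compound 1 to compound 3 (0.40 log units; beyond the scatter). Going from fluoro to chloro gives no change at the digits printed from compound 2 to compound 3 (within the scatter). All three swap one halogen for another, and none involves hydroxy, so they offer only a rough scale and no firm direction. Compound 3 already shares the lowest number, so a modest move towards a higher number seems the likelier outcome, though this is tentative. The expected change is a 2.5-fold higher number from compound 3 to compound 4 (0.40 log units; beyond the scatter). For compound 4 the estimated value is 150 nM, with an expected range of 50 nM to 500 nM.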

Compound 4, half-maximal inhibitory concentration: 120 nM
Beside the measured number, compound 4's estimate is 1.3-fold (0.10 log units) above it; low and high end bracket the measured number.
By their numbers in this assay, from the lowest: compounds 2, 3, 4 and 1 (each within the scatter of the next, the first and the last beyond it).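

Hydroxy is the first group at this position that is not a halogen, and it brings in a hydrogen-bond donor and a hydrogen-bond acceptor, yet in this assay replacing chloro with it gives a 2.0-fold higher number from compound 3 to compound 4 (0.30 log units; within the scatter) and so stays within the usual scatter. Replacing fluoro gives a 2.0-fold higher number from compound 2 to compound 4 (0.30 log units; within the scatter) and replacing bromo gives a 1.3-fold lower number from compound 1 to compound 4 (0.10 log units; within the scatter) so compound 4 cannot be separated from any of the three halogen compounds, even though compound 1 and compound 3 are separated from each other. On this read-out, the position accepts hydroxy in place of a halogen without a step beyond the scatter, but no supporting measurement is available to say why the numbers fall this way.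

The compounds shown leave open whether an amine or a carboxylic acid in the same place would stay within this narrow band of numbers or move clearly outside it. They also leave open what a methoxy or ethoxy group would do here, which would show whether the hydroxy hydrogen matters to the result.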